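The compounds below may be only part of what the source reports. "The series", "measured", "known", "first", "only" and "open" are said of these compounds alone.

Within the data shown here, compound 1 `COc1cc(OC)cc(-n2cc(-c3ccc(O)c(OC)c3)nn2)c1` is the only member of this small set to give a numerical result: in a functional assay on MDA-MB-231 cells (Homo sapiens) for cytotoxicity, read by MTT assay (a higher number here means a weaker inhibitor, a lower number a stronger inhibitor), compound 1 gives 10000 nM, which places it among weak inhibitors. Compound 2 `COc1cc(OC)cc(-c2cn(-c3ccc(OC)c(O)c3)nn2)c1` reaches only a limit of this assay, > 10000 nM. Compound 3 `COc1cc(-c2cn(-c3cc(OC)c(OC)c(OC)c3)nn2)ccc1O` carries methoxy in place of hydrogen on an aromatic carbon relative to compound 1. Among the measured compounds shown here, with no measured pair of this kind to draw on, the step from compound 1 to compound 3 is expected to stay within the scatter, no change at the digits printed from compound 1 to compound 3 (within the scatter). Compound 3 is therefore estimated at 10000 nM, with a range from 4000 nM to 30000 nM, and a real chance that this assay returns only a limit.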

Compound 3, half-maximal inhibitory concentration: > 10000 nM
Compound 3: no number, only a limit; the forecaster's own chance of this, stated with the estimate: 45%; the middle value lies on the limit itself.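

In this assay methoxy in place of hydrogen on an aromatic carbon, ortho to two methoxy groups and para to a large group, gives a number no lower from compound 1 to compound 3 (the limit leaves the size open) and so brings no gain in strength at this position. Among these compounds, this is the first direct reading of a change at this position on the core of compound 1. The size of the step cannot be read, because compound 3 gives a limit and not a number: the limit of > 10000 nM in this assay, at which 2 of the 3 values shown sit.

Going by these compounds, whether fluorine, an amine or a carboxylic acid at this same position would give a readable number remains open.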